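Swapping trifluoromethyl for fluoro on a cell-killing scaffold

A few compounds are considered here, and "the series" means these few. Any claim that something is new, unique, unknown or untested is made for them only; others in the source may bear on it.

Of the compounds shown here, three built on one shared core have been tested in a functional assay on OE19 cells (Homo sapiens) for cytotoxicity, read by MTT assay, with a stated time of 48 h; on this read-out higher numbers stand for weaker inhibition and lower numbers for stronger inhibition. Compound 1 `CC1(C)S[C@@H]2/C(=C\C(=O)c3ccc(C(F)(F)F)cc3)C(=O)N2[C@H]1C(=O)OC(c1ccccc1)c1ccccc1` gives 15600 nM. Compound 3 `CC1(C)S[C@@H]2/C(=C\C(=O)OC(c3ccccc3)c3ccccc3)C(=O)N2[C@H]1C(=O)OC(c1ccccc1)c1ccccc1` gives 21600 nM, a number that lies within the usual scatter of compound 1, so the two cannot be told apart. Compound 2 `CC1(C)[C@H](C(=O)OC(c2ccccc2)c2ccccc2)N2C(=O)/C(=C/C(=O)c3ccc([N+](=O)[O-])cc3)[C@H]2[S+]1[O-]` gives 92400 nM, a higher number that lies beyond the scatter and therefore marks weaker inhibition than compound 1.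

Compound 4 `CC1(C)S[C@@H]2/C(=C\C(=O)c3ccc(F)cc3)C(=O)N2[C@H]1C(=O)OC(c1ccccc1)c1ccccc1` has not yet been measured. It differs from compound 1 in one place: fluoro in place of trifluoromethyl on an aromatic carbon. Among the measured compounds shown here, no measured pair shows this exact change, so there is no step to lean on. Given that all three measured numbers sit in the same broad region, the expected step from compound 1 to compound 4 is small, likely none beyond the scatter, with a slight lean toward a higher number, a 1.3-fold higher number from compound 1 to compound 4 (0.11 log units; within the scatter). On that basis compound 4 is estimated at 20000 nM, within a range from 8000 nM to 50000 nM.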

Compound 4, half-maximal inhibitory concentration: 12100 nM
Compound 4: middle estimate off by 1.7-fold (0.22 log units), on the high side, within the range that was stated.
By their numbers in this assay, from the lowest: compounds 4, 1 and 3 (each within the scatter of the next); then compound 2.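

Putting fluoro in place of trifluoromethyl on this aromatic carbon gives a 1.3-fold lower number from compound 1 to compound 4 (0.11 log units; within the scatter) in this assay. Among the compounds shown here, this is the first direct reading of a change at this place, and it shows that the assay cannot tell these two groups apart, even though a group of 4 heavy atoms gives way to one of 1 heavy atom. Nothing measured here offers an explanation for this result.

With only these two groups compared at this place on the shared core, the step says little about the place in general. As far as these compounds go, whether an amine, a methoxy group or a carboxylic acid on the same aromatic carbon would move the number beyond the scatter remains open.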